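Replacing a nitrophenyl with a chlorophenyl on the same core

A few compounds are considered here, and "the series" means these few. Any claim that something is new, unique, unknown or untested is made for them only; others in the source may bear on it.

Compound 1, `COc1cc2c(cc1OC)C(=O)C(CC1CCN(C(=S)Nc3ccc(C)cc3)CC1)C2`: 30 mg/kg
Compound 2, `COc1cc2c(cc1OC)C(=O)C(CC1CCN(C(=S)Nc3ccccc3[N+](=O)[O-])CC1)C2`: 100 mg/kg
Compound 3, `COc1cc2c(cc1OC)C(=O)C(CC1CCN(C(=S)Nc3ccc([N+](=O)[O-])cc3)CC1)C2`: 30 mg/kg

All three compounds share one core and differ only in the aryl group on an amide-type nitrogen. In a functional assay on the whole organism (strain Swiss albino) with Mus musculus as the target, in the maximal electroshock model, with a stated time of 0.5 h (a lower number here means that less compound is needed, a higher number that more compound is needed for the effect), compound 2 gives the highest number of the three, so the most compound is needed for the effect. Two steps carry the information: a 3.3-fold lower number from compound 2 to compound 3 (0.52 log units; beyond the scatter) and a 3.3-fold higher number from compound 1 to compound 2 (0.52 log units; beyond the scatter). By contrast, no change at the digits printed from compound 1 to compound 3 (within the scatter), so 4-methylphenyl and 4-nitrophenyl behave alike, and only 2-nitrophenyl stands out.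

Compound 4, `COc1cc2c(cc1OC)C(=O)C(CC1CCN(C(=S)Nc3ccc(Cl)cc3)CC1)C2`, has not yet been tested. The change from compound 2 is 4-chlorophenyl in place of 2-nitrophenyl on an amide-type nitrogen. Because a 3.3-fold lower number from compound 2 to compound 3 (0.52 log units; beyond the scatter), moving away from 2-nitrophenyl to another aryl group is expected to bring the number back down, and a 4-chlorophenyl group is expected to sit with the other 4-substituted phenyls. The expected step is therefore a 3.3-fold lower number from compound 2 to compound 4 (0.52 log units; beyond the scatter). Compound 4 is estimated at 30 mg/kg in this assay, within a range from 15 mg/kg to 100 mg/kg.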

Compound 4, minimum effective dose: 30 mg/kg
Compound 4: middle estimate and measured number agree at the digits printed, within the range that was stated.
By their numbers in this assay, from the lowest: compounds 1, 3 and 4 (each within the scatter of the next); then compound 2.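

In this assay, a second group besides the 4-nitrophenyl of compound 3 now lowers the number relative to the 2-nitrophenyl of compound 2 (a 3.3-fold lower number from compound 2 to compound 4 (0.52 log units; beyond the scatter)). On the amide-type nitrogen, 4-chlorophenyl also reads the same as the other two aryl groups (no change at the digits printed from compound 3 to compound 4 (within the scatter); no change at the digits printed from compound 1 to compound 4 (within the scatter)), so compound 1, compound 3 and compound 4 form a group of three, with compound 2 the only one against that pattern. No measured evidence here explains this pattern.

As far as these compounds go, it remains open whether a chlorine in the place the nitro group holds in 2-nitrophenyl would give a number like that of compound 2 or like that of compound 4. From the compounds shown here alone, it is also open how a phenyl group carrying an amine or a carboxylic acid would read.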